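A Furan Ring Replaces Fluorophenyl on the Shared Core

The compounds below may be only part of what the source reports. "The series", "measured", "known", "first", "only" and "open" are said of these compounds alone.

Among the compounds with values here, compound 1 `O=C(Nc1ccc2nc(NC(=O)C3CCCCC3)sc2c1)c1cccc(F)c1` is one of three compounds measured in a functional assay on WI-38 VA13 cells (Homo sapiens) for cytotoxicity (a lower number here means that less compound is needed, a higher number that more compound is needed for the effect), and gives 0.64 ug/mL, the second highest of the three numbers. Compound 2 `O=C(Nc1ccc2nc(NC(=O)C3CCCCC3)sc2c1)c1c(Cl)cccc1Cl` gives 0.015 ug/mL, and compound 3 `CC(=O)Nc1ccc2nc(NC(=O)C3CCCCC3)sc2c1` gives 2.7 ug/mL. Compound 4 `Cc1coc(C)c1C(=O)Nc1ccc2nc(NC(=O)C3CCCCC3)sc2c1` differs from compound 1 by 2,4-dimethylfuran-3-yl in place of 3-fluorophenyl on a carbonyl carbon. Both earlier steps at this carbonyl carbon were large and ran in opposite directions: a 43-fold lower number from compound 1 to compound 2 (1.63 log units; beyond the scatter), while a 4.2-fold higher number from compound 1 to compound 3 (0.63 log units; beyond the scatter). An aromatic ring in this place has so far given lower numbers than methyl, the 2,6-dichlorophenyl ring the lowest. A lower number of modest size is therefore expected for the new aromatic ring. Compound 4 is estimated to give 0.25 ug/mL, between 0.05 ug/mL and 1.2 ug/mL. The expected step is a 2.6-fold lower number from compound 1 to compound 4 (0.41 log units; beyond the scatter).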

Compound 4, half-maximal effective concentration: 2.7 ug/mL
For compound 4 the middle estimate is 11-fold (1.03 log units) below the measured one, outside the stated range (above it).
By their numbers in this assay, from the lowest: compound 2; then compound 1; then compounds 3 and 4 (each within the scatter of the next).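

There is no change at the digits printed from compound 3 to compound 4 (within the scatter) in this assay when 2,4-dimethylfuran-3-yl replaces methyl, so an aromatic ring on this carbonyl carbon does not by itself give a lower number than methyl. Which ring stands here matters greatly: there is a 4.2-fold higher number from compound 1 to compound 4 (0.63 log units; beyond the scatter) and also a 180-fold higher number from compound 2 to compound 4 (2.26 log units; beyond the scatter) among these three rings. Nothing available here gives a reason for these differences.

Still open, going by these compounds, is whether the furan ring or its two methyl groups set the number of compound 4. Also open, on these data alone, is where an unsubstituted furan-3-yl or an unsubstituted phenyl would fall.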